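Ether group change at the shared core: compound 2 to 3

A few compounds are considered here, and "the series" means these few. Any claim that something is new, unique, unknown or untested is made for them only; others in the source may bear on it.

Measured so far:
compound 1 `O=C1OCCN1C(=O)c1ccc(Oc2ccc(O)cc2)cc1` — in an assay on HEK293 cells for inhibition of N-acylethanolamine-hydrolyzing acid amidase (Rattus norvegicus), read by LC-MS, with a stated time of 30 min (on this read-out lower numbers stand for stronger inhibition and higher numbers for weaker inhibition), compound 1 gives only the limit > 20000 nM, not a number.
compound 2 `O=C1OCCN1C(=O)c1ccc(OC2CCCCC2)cc1` — in this assay compound 2 gives 92 nM.
compound 3 `CCC(CC)Oc1ccc(C(=O)N2CCOC2=O)cc1` — not yet measured.

Compound 2 carries the only number shown in this assay; the one further value is a limit (the limit of > 20000 nM in this assay, at which 1 of the 2 values shown sits). Among the measured compounds shown here, the single measured step is an at least 210-fold lower number from compound 1 to compound 2 (2.33 log units; beyond the scatter), a swap of one group on the ether oxygen for another, and it is the only guide to what that oxygen tolerates.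

The change to compound 3 is pentan-3-yl in place of cyclohexyl on an oxygen on an aromatic ring. The measured step from compound 1 replaced an aromatic ring bearing a hydroxyl with a saturated ring; the present step exchanges that saturated ring for a branched chain. For the measured compounds named here, no measured step covers a ring-to-chain exchange at this oxygen, so the step of a 1.6-fold higher number from compound 2 to compound 3 (0.21 log units; within the scatter) is expected to be small, within or near the scatter, with any drift toward a higher number. Compound 3 is estimated at 150 nM with a range of 40 nM to 600 nM.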

Compound 3, half-maximal inhibitory concentration: 480 nM
Compound 3: middle estimate off by 3.2-fold (0.51 log units), on the low side, within the range that was stated.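

In this assay, exchanging the ring for a branched chain at this oxygen is not neutral: a 5.2-fold higher number from compound 2 to compound 3 (0.72 log units; beyond the scatter), which leaves compound 2 with the lowest number of the three compounds. A saturated ring is nonetheless not required for a large gain over 4-hydroxyphenyl, as pentan-3-yl also gives a much lower number, with an at least 41-fold lower number from compound 1 to compound 3 (1.61 log units; beyond the scatter). That step rests on a limit for compound 1, so its true size remains unknown: the limit of > 20000 nM in this assay, at which 1 of the 3 values shown sits.

The shift from cyclohexyl to pentan-3-yl removes the ring and also changes the carbon count, and the compounds shown do not separate these two differences; a cyclopentyl group or a straight pentyl chain on the same oxygen would bear directly on that question. From the compounds shown here alone, it also remains open whether the weak reading of compound 1 goes with the aromatic ring or with its hydroxyl, a question that an unsubstituted phenyl group on this oxygen would address.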